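A 3-hydroxyphenyl group replaces the bromophenyl arm

The source may hold more compounds than are shown below. What is called first, only, known or untested is meant among the compounds shown, and "the series" means these compounds.

Values in a functional assay on NCI-H460 cells (Homo sapiens) for inhibition, read by MTT assay, with a stated time of 72 h; a lower number here means a stronger inhibitor, a higher number a weaker inhibitor:
compound 1 `COc1cc(NC(C)CCCNC(=O)Nc2cccc(F)c2)c2ncccc2c1`: 24000 nM
compound 2 `COc1cc(NC(C)CCCNC(=O)NNC(=O)Nc2ccc(Cl)cc2)c2ncccc2c1`: 63000 nM
compound 3 `COc1cc(NC(C)CCCNC(=O)NNC(=O)Nc2ccc(Br)cc2)c2ncccc2c1`: 27000 nM

Compound 3 stands level with compound 1, shown by a 1.1-fold higher number from compound 1 to compound 3 (0.05 log units; within the scatter), and under compound 2, shown by a 2.3-fold lower number from compound 2 to compound 3 (0.37 log units; beyond the scatter). Compound 4 `COc1cc(NC(C)CCCNC(=O)Nc2cccc(O)c2)c2ncccc2c1` carries 3-hydroxyphenyl in place of ((4-bromophenyl)carbamoyl)amino on an amide-type nitrogen. Compound 1 differs from the others at that same place, and the steps there were small: a 1.1-fold higher number from compound 1 to compound 3 (0.05 log units; within the scatter) and a 2.6-fold higher number from compound 1 to compound 2 (0.42 log units; beyond the scatter). Going by the values given here, no measured compound carries 3-hydroxyphenyl, so no step beyond the scatter is expected in this assay, and the estimated change is a 1.1-fold lower number from compound 3 to compound 4 (0.03 log units; within the scatter). For compound 4 the expected value is 25000 nM, with an estimated range of 10000 nM to 60000 nM.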

Compound 4, half-maximal inhibitory concentration: 25000 nM
Beside the measured number, compound 4's estimate shows no gap at the digits printed; low and high end bracket the measured number.
By their numbers in this assay, from the lowest: compounds 1, 4 and 3 (each within the scatter of the next); then compound 2.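

In this assay the 3-hydroxyphenyl arm on the amide-type nitrogen stands level with the ((4-bromophenyl)carbamoyl)amino arm (a 1.1-fold lower number from compound 3 to compound 4 (0.03 log units; within the scatter)), yet it gives a lower number than the ((4-chlorophenyl)carbamoyl)amino arm (a 2.5-fold lower number from compound 2 to compound 4 (0.40 log units; beyond the scatter)). Hydroxy in place of fluoro on the aromatic carbon also leaves the two compounds level (a 1.0-fold higher number from compound 1 to compound 4 (0.02 log units; within the scatter)), so this ring accepts either substituent without a step beyond the scatter. No measured evidence accounts for these results. Going by these compounds, whether an amine or a carboxylic acid on that aromatic carbon would keep the number at this level remains open.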